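One Methyl Added Twice: Estimating Compound 4

The compounds below may be only part of what the source reports. "The series", "measured", "known", "first", "only" and "open" are said of these compounds alone.

Measured so far in an in vitro functional assay on cells (Fibroblast) for agonist activity at Alpha-1D adrenergic receptor (Homo sapiens); on this read-out lower numbers stand for an effect already at smaller amounts and higher numbers for an effect only at larger amounts of compound:
compound 1, `Cn1ncnc1-c1ccccc1NCC1=NCCN1`, compound 1 gives 63.1 nM
compound 2, `CCn1ncnc1-c1ccccc1NCC1=NCCN1`, compound 2 gives 126 nM
compound 3, `Cn1cccc1-c1ccccc1NCC1=NCCN1`, compound 3 gives 251 nM

The change from compound 1 to compound 2 is methyl in place of hydrogen on a saturated chain carbon bound to an aromatic nitrogen. In this assay it made a 2.0-fold higher number from compound 1 to compound 2 (0.30 log units; within the scatter), a step that stays within the scatter of repeated measurements.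

Compound 4, `CCn1cccc1-c1ccccc1NCC1=NCCN1`, has not yet been measured. Among the compounds with values here, it differs from compound 3 by methyl in place of hydrogen on a saturated chain carbon bound to an aromatic nitrogen, the same kind of change as the one from compound 1 to compound 2, at a place described in the same words. The two cores themselves differ by 1-methyl-1H-pyrrol-2-yl in place of 1-methyl-1H-1,2,4-triazol-5-yl on an aromatic carbon, and that change made a 4.0-fold higher number from compound 1 to compound 3 (0.60 log units; beyond the scatter), so compound 3 stands at the highest number of the three measured compounds.

For compound 4 in this assay a step of about a 2.0-fold higher number from compound 3 to compound 4 (0.30 log units; within the scatter) is expected, resting on the earlier step of a 2.0-fold higher number from compound 1 to compound 2 (0.30 log units; within the scatter) seen on the core of compound 1. Compound 4 is therefore estimated at 500 nM, with a likely range from 200 nM to 1250 nM.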

Compound 4, half-maximal effective concentration: < 100000 nM
Compound 4 gave a limit, no number; the forecaster's own chance of this, stated with the estimate: 5%; the middle value is on the limit's open side.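

In this assay compound 4 gives < 100000 nM, which is a limit of the assay and not a number. The step from compound 3 to compound 4 therefore cannot be read. The compounds shown leave open whether methyl in place of hydrogen at this place shifts the number on the core of compound 3 as it did on the core of compound 1.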